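The source may report more compounds than this note shows. Statements on the series, on what has been measured and on what is new or still open speak of the compounds shown alone.

Compound 3 `CC(C)(C)OC(=O)NCCCC[C@H](NC(=O)CN(c1ncnc2c1ncn2C1CCCCO1)C1CC1)C(=O)OCc1ccccc1` gives 18.3% in a functional assay on the whole organism (Tail, strain ICR) with Mus musculus as the target, in the tail flick test, with a stated time of 30 min, at a dose of 25 umol/kg by the oral route (on this read-out higher numbers stand for a stronger effect at the one dose given and lower numbers for a weaker effect), the lowest of the three numbers measured. Compound 2 `CC[C@H](C)[C@H](NC(=O)CN(c1ncnc2c1ncn2C1CCCCO1)C1CC1)C(=O)OCc1ccccc1` gives 25.6%, a gap that stays within the scatter, while compound 1 `NC(=O)CC[C@H](NC(=O)CN(c1ncnc2c1ncn2C1CCCCO1)C1CC1)C(=O)OCc1ccccc1` gives 47%. Compound 4 `NC(=O)C[C@H](NC(=O)CN(c1ncnc2c1ncn2C1CCCCO1)C1CC1)C(=O)OCc1ccccc1` has not yet been measured; it differs from compound 3 in that (carbamoyl in place of 3-((tert-butoxycarbonyl)amino)propyl on a saturated chain carbon, two bonds along the chain from an amide-type nitrogen and a carbonyl carbon). The closest comparison is a change of the reverse kind, which brought a number 28.7 percentage points lower from compound 1 to compound 3 (beyond the scatter); removing the carbamoyl group also cost activity in a number 21.4 percentage points lower from compound 1 to compound 2 (beyond the scatter). Restoring a carbamoyl group is therefore expected to raise the number, and the step expected is a number 21.7 percentage points higher from compound 3 to compound 4 (beyond the scatter). Compound 4 is estimated at 40%, within a range from 22% to 58%.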

Compound 4, a percentage reported as activity, at one dose (the size of the read-out at that dose, not a potency): 34.5%
Compound 4: the middle estimate sits 5.5 percentage points above what was measured; the range from low to high includes it.
By their numbers in this assay, from the lowest: compounds 3, 2 and 4 (each within the scatter of the next, the first and the last beyond it); then compound 1.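

Chain length counts at this position: the carbamoyl-ended side chain of compound 1 loses activity when shortened by one carbon, carbamoyl in place of carbamoylmethyl (a number 12.5 percentage points lower from compound 1 to compound 4 (beyond the scatter)). The shorter chain still stands clear of the long protected chain (a number 16.2 percentage points higher from compound 3 to compound 4 (beyond the scatter)), but it cannot be told apart from sec-butyl (a number 8.9 percentage points higher from compound 2 to compound 4 (within the scatter)), so a carbamoyl group alone does not set activity here. No measurement shown explains these gaps. Open, from the compounds shown here alone, is how a carbamoyl group on a chain longer than in compound 1 would compare. Also open, going by these compounds, is how a carboxylic acid or free amine would fare at this position.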